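Dropping the Chloro Group from a Weak Coumarin Chalcone

A few compounds are considered here, and "the series" means these few. Any claim that something is new, unique, unknown or untested is made for them only; others in the source may bear on it.

This series is tested in a functional assay on NIH3T3 cells (Mus musculus) for cytotoxicity, read by sulforhodamine B assay, with a stated time of 48 h; on this read-out lower numbers stand for stronger inhibition and higher numbers for weaker inhibition. Of the compounds shown here, three have been measured. Compound 1 `CCC(C)c1cc(/C=C/C(=O)c2ccc(Cl)cc2)cc2cc(C(C)=O)c(=O)oc12` gives "not active" (no number reported), and no number is reported for it. Compound 2 `CCOC(=O)c1cc2cc(/C=C/C(=O)c3ccccc3)cc(C(C)CC)c2oc1=O` likewise gives "not active" (no number reported), again without a number. Among the measured compounds shown here, compound 3 `CCC(C)c1cc(/C=C/C(=O)c2ccc(Cl)cc2)cc2cc(C(=O)OC)c(=O)oc12` is the only member with a measured value: in this assay compound 3 gives 42400 nM, which places it as the sole compound in this small set with quantified, though weak, inhibition.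

The step now followed leads from compound 3 to compound 4 `CCC(C)c1cc(/C=C/C(=O)c2ccccc2)cc2cc(C(=O)OC)c(=O)oc12`, which has not yet been measured. The change is hydrogen in place of chloro on an aromatic carbon. For the measured compounds named here, no comparable step between measured compounds exists here, so there is no direct guide to its size. Given that compound 3 sits at 42400 nM and its two relatives give no number at all, the expected step of a 1.4-fold higher number from compound 3 to compound 4 (0.15 log units; within the scatter) is toward weaker inhibition, modest in size, with a fair chance that compound 4 also ends up with no number. Compound 4 is therefore estimated at 60000 nM, with a range from 30000 nM to 150000 nM.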

Compound 4, half-maximal inhibitory concentration: "not active" (no number reported)
No number was reported for compound 4, so the estimate cannot be set against anything.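

In this assay, among the compounds shown here, compound 4 is reported as not active, with no number, so no step from compound 3 to compound 4 can be read. Going by these compounds, how much swapping the chloro group for hydrogen changes cytotoxicity stays open. No evidence shown bears on this result.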